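Methyl for chloro: compound 2 to compound 4

The source may hold more compounds than are shown below. What is called first, only, known or untested is meant among the compounds shown, and "the series" means these compounds.

Working notes on the series. Compound 1 `Clc1ccc(NCc2cn(-c3ccccc3)nc2-c2ccc(Cl)cc2)cc1` gives in an ADME assay on BHK-21 cells (Mesocricetus auratus) for cytotoxicity, read by MTT assay, with a stated time of 72 h (on this read-out lower numbers stand for higher toxicity in this test and higher numbers for lower toxicity in this test), a value of 73000 nM. Compound 2 `Cc1ccc(NCc2cn(-c3ccccc3)nc2-c2ccc(Cl)cc2)cc1` reaches only the limit of the read-out in this assay, recorded as > 100000 nM. Compound 3 `Brc1ccc(-c2nn(-c3ccccc3)cc2CNc2ccccc2)cc1` likewise sits at the limit in this assay, recorded as > 100000 nM. Compound 2 thus stands at the ceiling of what the read-out reports (the limit of > 100000 nM in this assay, at which 2 of the 3 values shown sit), with no number of its own.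

The unmeasured compound 4 `Cc1ccc(NCc2cn(-c3ccccc3)nc2-c2ccc(C)cc2)cc1` differs from compound 2 by methyl in place of chloro on an aromatic carbon. Going by the values given here, the only measured step of this kind, an at least 1.3-fold higher number from compound 1 to compound 2 (0.13 log units; that floor lies within the scatter), lies within the scatter. The step in this assay is therefore expected to be none beyond the scatter, a step that the limit leaves unreadable from compound 2 to compound 4. Compound 4 is expected to remain at the limit, estimated at 130000 nM within 60000 nM to 300000 nM.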

Compound 4, half-maximal cytotoxic concentration: > 100000 nM
Compound 4 was reported as a limit (the forecaster's own chance of this, stated with the estimate: 70%); the middle value is on the limit's open side.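

No step can be read from compound 2 to compound 4 in this assay as both values are limits and not numbers: the limit of > 100000 nM in this assay, at which 3 of the 4 values shown sit.
The compounds shown leave open how far past that limit compound 2 and compound 4 lie, and whether methyl in place of chloro shifts the read-out here.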